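This account rests on a few compounds, and the source may have more. Where it says the series, first, only, none or still open, it means among the compounds named here.

Measured compounds in an assay on HL-60 cells for agonist activity at N-formyl peptide receptor 3 (Homo sapiens), read by calcium flux; a lower number here means that less compound is needed, a higher number that more compound is needed for the effect:
compound 1 `Cc1cc(Cc2cccc(Br)c2)c(=O)n(CC(=O)Nc2ccc(Br)cc2)n1` gives > 50000 nM, a limit of the assay.
compound 2 `COc1cc(Cc2cc(C)nn(CC(=O)Nc3ccc(Br)cc3)c2=O)cc(OC)c1` gives > 50000 nM, a limit of the assay.
compound 3 `Cc1cc(Cc2cccc3ccccc23)c(=O)n(CC(=O)Nc2ccc(Br)cc2)n1` gives > 50000 nM, a limit of the assay.

Compound 2 stands at the limit; no number is known for it, and the same is true for the two other compounds, so all that can be said is the limit of > 50000 nM in this assay, at which 3 of the 3 values shown sit. The steps among the measured compounds, a step that the two limits leave unreadable from compound 1 to compound 2, a step that the two limits leave unreadable from compound 1 to compound 3 and a step that the two limits leave unreadable from compound 2 to compound 3, are therefore unreadable in size and direction; they say nothing about how the group on the saturated chain carbon bound to an aromatic carbon moves the readout.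

Compound 4 `COc1cc(Cc2cc(C)nn(CC(=O)Nc3ccc(I)cc3)c2=O)cc(OC)c1` is not yet measured. It differs from compound 2 by iodo in place of bromo on an aromatic carbon. For the measured compounds named here, none of the measured steps touches this position, and none yields a readable size, so no step of known size bears on the change. Given that compound 2 sits at the limit and that the one-atom change leaves donors, acceptors and charge as they are, the expectation is that compound 4 in this assay again shows no readable effect, with the estimated step that the limit leaves unreadable from compound 2 to compound 4. Compound 4 is estimated at 80000 nM, within 20000 nM to 300000 nM, most likely reported only as a limit.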

Compound 4, half-maximal effective concentration: > 50000 nM
Compound 4 ended at the assay's limit (the forecaster's own chance of this, stated with the estimate: 85%); the middle value lies beyond the limit too.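

No new step can be read: in this assay neither compound 2 nor compound 4 has a number, so iodo in place of bromo has no readable size. The series rests on a single limit: the limit of > 50000 nM in this assay, at which 4 of the 4 values shown sit. The compounds shown leave open whether any change to the shared core gives a measurable response in this assay.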